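Chloro for Hydroxy on the Aryl Ketone Ring

The source may report more compounds than this note shows. Statements on the series, on what has been measured and on what is new or still open speak of the compounds shown alone.

Compound 1 `COc1ccc(C(=O)/C=C/c2cc3ccccc3[nH]c2=O)cc1`: 3140 nM in a functional assay on DU-145 cells (Homo sapiens) for cytotoxicity, read by sulforhodamine B assay, with a stated time of 24 h; a higher number here means a weaker inhibitor of growth, a lower number a stronger inhibitor of growth
Compound 2 `O=C(/C=C/c1cc2ccccc2[nH]c1=O)c1ccc(O)cc1`: 4020 nM in this assay

Compound 2 stands at the higher of the two numbers in this assay, yet the step of a 1.3-fold higher number from compound 1 to compound 2 (0.11 log units; within the scatter) is within the scatter, so the two cannot be told apart. Compound 3 `O=C(/C=C/c1cc2ccccc2[nH]c1=O)c1ccc(Cl)cc1` carries chloro in place of hydroxy on an aromatic carbon, on an aromatic carbon of a six-membered aromatic ring of carbon only, para to a large group. For the measured compounds named here, the only measured step, a 1.3-fold higher number from compound 1 to compound 2 (0.11 log units; within the scatter), alters the same place with other groups and stayed within the scatter. Compound 3 is therefore expected to give a number near that of compound 2, with a step of a 1.3-fold lower number from compound 2 to compound 3 (0.13 log units; within the scatter) within the scatter. The estimate for compound 3 is 3000 nM, ranging from 1000 nM to 9000 nM.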

Compound 3, concentration for 50% growth inhibition: 4080 nM
Compound 3: middle estimate off by 1.4-fold (0.13 log units), on the low side; measured number inside the range.
By their numbers in this assay, from the lowest: compounds 1, 2 and 3 (each within the scatter of the next).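

In this assay, replacing hydroxy with chloro gives a 1.0-fold higher number from compound 2 to compound 3 (0.01 log units; within the scatter), and replacing methoxy with chloro gives a 1.3-fold higher number from compound 1 to compound 3 (0.11 log units; within the scatter). This position, para to a large group, has now carried three groups with no step beyond the scatter, even though hydroxy has a hydrogen-bond donor and acceptor and chloro has neither. No evidence here bears on this result. Going by these compounds, whether an amine, a carboxylic acid or a longer alkoxy chain here would move the number beyond the scatter remains open, as does the effect of changes elsewhere on the shared core.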